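Cyclopropyl for bromo: an untested step from compound 2

A few compounds are considered here, and "the series" means these few. Any claim that something is new, unique, unknown or untested is made for them only; others in the source may bear on it.

Compound 2, `CC1CC/C(=N\Nc2ccc(Br)cc2)c2ncc(C(=O)O)c(=O)n21`, belongs to a small set of three measured compounds sharing one core and differing only in the aryl group on an amine nitrogen. In a functional assay on the whole organism for inhibition, with Rattus norvegicus as the target (a higher number here means that more compound is needed for the effect, a lower number that less compound is needed), compound 2 reaches only a limit, > 1000 umol/kg. Compound 1, `CC1CC/C(=N\Nc2cccc(Cl)c2)c2ncc(C(=O)O)c(=O)n21`, likewise gives a limit in this assay, > 100 umol/kg. Compound 3, `Cc1ccccc1N/N=C1\CCC(C)n2c1ncc(C(=O)O)c2=O`, also stops at a limit in this assay, > 100 umol/kg. Every one of the three values is a limit, and they sit at two places: the limit of > 100 umol/kg in this assay, at which 2 of the 3 values shown sit, and (the limit of > 1000 umol/kg in this assay, at which 1 of the 3 values shown sits). The steps among them are therefore unreadable: a step that the two limits leave unreadable from compound 1 to compound 2, a step that the two limits leave unreadable from compound 1 to compound 3, and a step that the two limits leave unreadable from compound 2 to compound 3.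

Compound 4, `CC1CC/C(=N\Nc2ccc(C3CC3)cc2)c2ncc(C(=O)O)c(=O)n21`, differs from compound 2 by a single change: cyclopropyl in place of bromo on an aromatic carbon. Going by the values given here, no measured step bears on this change in a readable way, since none of the three measured steps could be sized. Nothing in the measured values points to a direction for this step, and the author expects no step beyond the scatter, with compound 4 most likely again ending at a limit. Compound 4 is expected to give about 1000 umol/kg in this assay, within 100 umol/kg to 10000 umol/kg. The expected step is a number no higher from compound 2 to compound 4 (the limit leaves the size open).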

Compound 4, dose for 50% inhibition: 100 umol/kg
For compound 4 the middle estimate is 10-fold (1.00 log units) above the measured one; measured number inside the range.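

Cyclopropyl in place of bromo on an aromatic carbon, para to a large group, gives an at least 10-fold lower number from compound 2 to compound 4 (1.00 log units; beyond the scatter) in this assay, the first step in this set whose direction can be read. In this assay compound 4 gives 100 umol/kg, a number rather than a limit, so the aryl group on the amine nitrogen is shown for the first time to be a place where a single change moves the read-out beyond the scatter. The step has a lower bound only, as the value of compound 2 is a limit: the limit of > 1000 umol/kg in this assay, at which 1 of the 4 values shown sits.

The compounds shown leave open whether this step belongs to the three-membered ring itself or would also come with an open chain such as isopropyl, or with an amine, on the same aromatic carbon. They also leave open whether cyclopropyl would give a similar step at another place on the six-membered aromatic ring, and they give no reason for the step seen here.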